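The compounds below may be only part of what the source reports. "The series", "measured", "known", "first", "only" and "open" are said of these compounds alone.

In a functional assay on SUP-B15 cells (Homo sapiens) for antiproliferative activity, with a stated time of 72 h (a lower number here means that less compound is needed, a higher number that more compound is needed for the effect), compound 1 `COc1ccc(-c2cc(=O)c3c(OC)cc(OC)cc3n2Cc2ccccc2)cc1` reaches only (the limit of > 34400 nM in this assay, at which 1 of the 3 values shown sits), so its reading of > 34400 nM is a limit of the assay and not a number. Compound 2 `COC(=O)c1cc(=O)c2c(OC)cc(OC)cc2[nH]1` gives 16100 nM in this assay, and compound 3 `COc1ccc(-c2cc(=O)c3c(OC)cc(OC)cc3n2S(=O)(=O)c2c(C(C)C)cc(C(C)C)cc2C(C)C)cc1` gives 43300 nM, both weak. Compound 4 `COc1ccc(-c2cc(=O)c3c(OC)cc(OC)cc3n2S(=O)(=O)Cc2ccccc2)cc1` differs from compound 1 by benzylsulfonyl in place of benzyl on an aromatic nitrogen. Compound 3 also carries a sulfonyl group on its nitrogen and gives 43300 nM in this assay, which is about where compound 1 already stands. No step beyond the usual scatter is therefore expected, a step that the limit leaves unreadable from compound 1 to compound 4. Compound 4 is estimated at 40000 nM, within a range from 15000 nM to 120000 nM, and it may well be that this assay again reports only a limit for compound 4.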

Compound 4, half-maximal effective concentration: > 34400 nM
Compound 4 ended at the assay's limit; the forecaster's own chance of this, stated with the estimate: 50%; the middle value is on the limit's open side.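

Among these compounds, compound 1 and compound 4 both stop at a limit of the assay rather than a number, so no step between them can be read: the limit of > 34400 nM in this assay, at which 2 of the 4 values shown sit. The compounds shown leave open whether benzylsulfonyl in place of benzyl on the aromatic nitrogen changes antiproliferative activity at all.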